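A few compounds are considered here, and "the series" means these few. Any claim that something is new, unique, unknown or untested is made for them only; others in the source may bear on it.

Three compounds share one core, a hydrazone linked to a benzamide that carries a morpholine sulfonyl group, and differ only in the phenyl ring attached to the carbon double-bonded to nitrogen. Compound 1 `C/C(=N\NC(=O)c1cccc(S(=O)(=O)N2CCOCC2)c1)c1ccc(O)cc1` carries a 4-hydroxyphenyl there. In a functional assay on PC-3 cells (Homo sapiens) for antiproliferative activity, read by MTT assay, with a stated time of 72 h (on this read-out lower numbers stand for stronger inhibition and higher numbers for weaker inhibition), compound 1 gives 36200 nM. Compound 2 `C/C(=N\NC(=O)c1cccc(S(=O)(=O)N2CCOCC2)c1)c1cc(O)ccc1O` carries a 2,5-dihydroxyphenyl instead. In this assay compound 2 reaches only the limit of the measurement, > 100000 nM, so its true value is not known, only that it is weak (the limit of > 100000 nM in this assay, at which 1 of the 2 values shown sits). The step of an at least 2.7-fold higher number from compound 1 to compound 2 (0.44 log units; beyond the scatter) therefore shows a loss of potency of unknown full size.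

Compound 3 `C/C(=N\NC(=O)c1cccc(S(=O)(=O)N2CCOCC2)c1)c1cc(Br)ccc1O` differs from compound 2 by bromo in place of hydroxy on an aromatic carbon. Going by the values given here, no measured step covers this exchange; the only measured step, from compound 1 to compound 2, changes a different substitution pattern, so it gives no direct guide to direction or size. Starting from a limit, compound 3 is expected to stay weak, with an estimated step of an at least 1.2-fold lower number from compound 2 to compound 3 (0.09 log units; that floor lies within the scatter) that cannot be resolved against the scatter. Compound 3 is expected to give about 80000 nM, within a range from 30000 nM to 200000 nM, and may again be reported only as a limit.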

Compound 3, half-maximal inhibitory concentration: 6890 nM
Compound 3: middle estimate off by 12-fold (1.06 log units), on the high side; measured number below the stated range.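

In this assay, going by these compounds alone, putting bromo in place of hydroxy, para to a hydroxy group, gives an at least 14-fold lower number from compound 2 to compound 3 (1.16 log units; beyond the scatter), so this position responds strongly to the group it carries, which the earlier compounds could not show. Compound 2 stands only at a limit of the measurement, so this step gives a floor and not a full size: the limit of > 100000 nM in this assay, at which 1 of the 3 values shown sits. The loss of potency seen with 2,5-dihydroxyphenyl therefore does not extend to every ring with a group at this position, since 5-bromo-2-hydroxyphenyl in place of 4-hydroxyphenyl gives a 5.3-fold lower number from compound 1 to compound 3 (0.72 log units; beyond the scatter), a gain over the ring of compound 1.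

The compounds shown leave open whether the gain belongs to bromo itself or comes simply from removing that hydroxy group; chloro, methyl or methoxy at the same position would help separate the two. They also leave open whether the hydroxy group that remains in 5-bromo-2-hydroxyphenyl is needed, a question that a phenyl ring carrying bromo alone would address.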